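A few compounds are considered here, and "the series" means these few. Any claim that something is new, unique, unknown or untested is made for them only; others in the source may bear on it.

Of the compounds shown here, three built on a shared core have been tested in a functional assay on SF-539 cells (Homo sapiens) for inhibition; on this read-out lower numbers stand for stronger inhibition of growth and higher numbers for weaker inhibition of growth: compound 1 `COc1cc(/C=C/c2ccc(S(N)(=O)=O)cc2)cc(OC)c1` gives 18800 nM, compound 2 `NS(=O)(=O)c1ccc(/C=C/c2ccc(O)c(O)c2)cc1` gives 14200 nM, and compound 3 `NS(=O)(=O)c1ccc(/C=C/c2ccc(F)cc2)cc1` gives 29100 nM. Compound 3 sits within the usual scatter of compound 1, and its number lies just beyond the scatter above that of compound 2. Compound 4 `NS(=O)(=O)c1ccc(/C=C/c2ccc(O)cc2)cc1` differs from compound 3 in one place: hydroxy in place of fluoro on an aromatic carbon. Within the data shown here, no measured pair shows this change alone. Among the measured compounds shown here, the only hint is compound 2, which also carries hydroxy and gives 14200 nM. The expected change is a 1.6-fold lower number from compound 3 to compound 4 (0.21 log units; within the scatter), a small step towards stronger inhibition that may stay within the scatter. For compound 4 the estimated value is 18000 nM, with an expected range of 9000 nM to 35000 nM.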

Compound 4, concentration for 50% growth inhibition: 7400 nM
Compound 4: middle estimate off by 2.4-fold (0.39 log units), on the high side; the whole stated range lies above it.
By their numbers in this assay, from the lowest: compounds 4, 2, 1 and 3 (each within the scatter of the next, the first and the last beyond it).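

On this aromatic carbon, para to a large group, hydroxy in place of fluoro brings a step beyond the scatter (a 3.9-fold lower number from compound 3 to compound 4 (0.59 log units; beyond the scatter)), so this single change does alter growth inhibition. The second hydroxy of compound 2 adds nothing readable, since its replacement by hydrogen stays within the scatter (a 1.9-fold lower number from compound 2 to compound 4 (0.28 log units; within the scatter)). Nothing measured here gives a reason for the step from fluoro to hydroxy.

On these data alone, what an amine or a carboxylic acid would do on this same carbon stays open. So does whether a methoxy there would keep the stronger inhibition seen with hydroxy.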